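This account rests on a few compounds, and the source may have more. Where it says the series, first, only, none or still open, it means among the compounds named here.

Compound 1, `Cc1ccc(-c2c(C)c(-c3ccc(C)c(C)c3)c(C(OC(C)(C)C)C(=O)O)c(C)c2N)cc1C`, gives 12000 nM in an ADME assay on MT4 cells (Homo sapiens) for cytotoxicity, read by MTT assay, with a stated time of 4 days; a lower number here means that less compound is tolerated, a higher number that more compound is tolerated.
Compound 2, `CNC(=O)Nc1c(C)c(C(OC(C)(C)C)C(=O)O)c(-c2ccc(C)c(C)c2)c(C)c1-c1ccc(C)c(C)c1`, gives 20000 nM in this assay.
Compound 3, `Cc1ccc(-c2c(C)c(-c3ccc4c(c3C)CCCO4)c(C(OC(C)(C)C)C(=O)O)c(C)c2NS(C)(=O)=O)cc1C`, gives 24000 nM in this assay.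

Compound 2 sits in the middle of the three numbers, with compound 3 nearest and compound 1 furthest, and neither gap reaches beyond the scatter. Within the data shown here, the only measured step touching the nitrogen on the aromatic ring, a 1.7-fold higher number from compound 1 to compound 2 (0.22 log units; within the scatter), stayed within the scatter. Compound 4, `Cc1ccc(-c2c(C)c(-c3ccc(C)c(C)c3)c(C(OC(C)(C)C)C(=O)O)c(C)c2NC(=O)Nc2ccccc2)cc1C`, differs from compound 2 by phenyl in place of methyl on an amide-type nitrogen. No measured step exchanges a methyl for a phenyl at this amide-type nitrogen, so the expectation rests on the one step shown and is for a change of a 1.3-fold lower number from compound 2 to compound 4 (0.10 log units; within the scatter), not beyond the scatter. Compound 4 is therefore estimated at 16000 nM in this assay, within 7000 nM to 35000 nM.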

Compound 4, half-maximal cytotoxic concentration: 8000 nM
Compound 4: the middle estimate sits 2.0-fold (0.30 log units) above what was measured; the measured number falls inside the stated range.
By their numbers in this assay, from the lowest: compounds 4, 1, 2 and 3 (each within the scatter of the next, the first and the last beyond it).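

In this assay, among these compounds, the exchange of methyl for phenyl on the amide-type nitrogen gives the first step at this position to pass beyond the scatter (a 2.5-fold lower number from compound 2 to compound 4 (0.40 log units; beyond the scatter)). Measured against hydrogen on the nitrogen on the aromatic ring, however, the phenylcarbamoyl group stays within the scatter (a 1.5-fold lower number from compound 1 to compound 4 (0.18 log units; within the scatter)). Nothing given here accounts for this shift. Open, from the compounds shown here alone, is whether an ethyl chain or a benzyl group on the amide-type nitrogen falls nearer to methyl or to phenyl, and whether the step from methyl to phenyl holds on another core.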